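The compounds below may be only part of what the source reports. "The series", "measured", "known", "first", "only" and "open" are said of these compounds alone.

Compound 1 `COc1ccc(/C=C2\CCC/C(=C\c3cccc(OC)c3OC)C2=O)cc1` and compound 2 `COc1cccc(/C=C2\CCC/C(=C\c3cccc(O)c3)C2=O)c1OC` share one core and differ in a single aryl group. In a functional assay on MCF7 cells (Homo sapiens) for cytotoxicity, read by MTT assay, with a stated time of 72 h (on this read-out higher numbers stand for weaker inhibition and lower numbers for stronger inhibition), compound 1 gives 18600 nM, while compound 2 gives 8800 nM. The change 3-hydroxyphenyl in place of 4-methoxyphenyl on a double-bonded chain carbon bound to a double-bonded ring carbon gave a 2.1-fold lower number from compound 1 to compound 2 (0.33 log units; beyond the scatter). Compound 3 `COc1ccc(/C=C2\CCC/C(=C\c3ccc(OC)c(OC)c3)C2=O)cc1` is built from the same atoms as compound 1, joined differently; how the two cores differ is not broken down here. In this assay compound 3 gives 7800 nM, a number that lies within the usual scatter of that of compound 2. Compound 4 `COc1ccc(/C=C2\CCC/C(=C\c3cccc(O)c3)C2=O)cc1OC` carries the same change made on the core of compound 3: 3-hydroxyphenyl in place of 4-methoxyphenyl on a double-bonded chain carbon bound to a double-bonded ring carbon. Going by the values given here, the expected step is a 2.1-fold lower number from compound 3 to compound 4 (0.31 log units; beyond the scatter), resting on the one precedent a 2.1-fold lower number from compound 1 to compound 2 (0.33 log units; beyond the scatter). Compound 4 is therefore estimated at 3800 nM, between 1800 nM and 8000 nM.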

Compound 4, half-maximal inhibitory concentration: 2900 nM
For compound 4 the middle estimate is 1.3-fold (0.12 log units) above the measured one, within the range that was stated.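

In this assay, putting 3-hydroxyphenyl in place of 4-methoxyphenyl gave a 2.7-fold lower number from compound 3 to compound 4 (0.43 log units; beyond the scatter), and this step agrees with the earlier one on the other core: the same change on two cores in this assay, a 2.1-fold lower number (0.33 log units; beyond the scatter) from compound 1 to compound 2 and a 2.7-fold lower number (0.43 log units; beyond the scatter) from compound 3 to compound 4, 1.3-fold (0.10 log units) apart, within the scatter of two such steps. On these two cores, then, the change carried over in both direction and size. Going by these compounds alone, this rests on only two pairs in a single cell assay, so it does not show that the change would carry to other cores, nor does it explain why the numbers fall.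

The aryl groups shown carry only methoxy or hydroxy substituents. As far as these compounds go, how an amine, a carboxylic acid or a fluorine in place of the hydroxy group would behave on either core therefore remains open.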